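The compounds below may be only part of what the source reports. "The series", "measured", "known", "first", "only" and "open" are said of these compounds alone.

In a functional assay on HepG2 cells (Homo sapiens) for cytotoxicity, read by MTT assay, with a stated time of 72 h (a lower number here means a stronger inhibitor, a higher number a weaker inhibitor), compound 1 (`O=C1C=CCC/C1=C\C=C\c1ccc(F)cc1`) gives 2900 nM, compound 2 (`O=C1C=CCC/C1=C\C=C\c1ccc(Cl)cc1`) gives 3700 nM and compound 3 (`O=C1C=CCC/C1=C\C=C\c1ccc(Br)cc1`) gives 6100 nM. Compound 3 thus has the highest of the three numbers, though only its gap to compound 1 passes the scatter. The steps among these halogens stay small: a 1.3-fold higher number from compound 1 to compound 2 (0.11 log units; within the scatter), a 1.6-fold higher number from compound 2 to compound 3 (0.22 log units; within the scatter) and a 2.1-fold higher number from compound 1 to compound 3 (0.32 log units; beyond the scatter). Compound 4 (`CC(=O)Oc1ccc(/C=C/C=C2\CCC=CC2=O)cc1`) carries acetoxy in place of bromo on an aromatic carbon, para to a large group (acetoxy in place of bromo on an aromatic carbon). Within the data shown here, no measured compound holds an acetoxy group, so these modest steps are the only guide to size. The expected change is a 1.4-fold lower number from compound 3 to compound 4 (0.13 log units; within the scatter), so no shift beyond the scatter is expected. Compound 4 is estimated at 4500 nM, with an expected range of 2000 nM to 10000 nM.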

Compound 4, half-maximal inhibitory concentration: 4500 nM
For compound 4 middle estimate and measured number coincide at the digits printed, and the stated range covers the measured number.
By their numbers in this assay, from the lowest: compounds 1, 2, 4 and 3 (each within the scatter of the next, the first and the last beyond it).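

In this assay, among these compounds, the place para to a large group takes acetoxy, with more heavy atoms than any of the halogens and with hydrogen-bond acceptors, and no step goes beyond the scatter (a 1.4-fold lower number from compound 3 to compound 4 (0.13 log units; within the scatter)) (a 1.2-fold higher number from compound 2 to compound 4 (0.09 log units; within the scatter)) (a 1.6-fold higher number from compound 1 to compound 4 (0.19 log units; within the scatter)). Among the compounds shown here, the earlier compounds showed this only among halogens, so acetoxy is the first non-halogen group seen to sit within their range. No measured evidence bears on why this change leaves the number within the scatter. The compounds shown leave open how an amine or a carboxylic acid at this place would compare.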